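The source may hold more compounds than are shown below. What is called first, only, known or untested is meant among the compounds shown, and "the series" means these compounds.

In a functional assay on the whole organism for inhibition, with Rattus norvegicus as the target, read by cytopathic effect and paw edema, at a dose of 100 mg/kg by the oral route (a lower number here means less inhibition, a higher number more inhibition at the dose given (going by the name of the read-out)), compound 1 `O=C(Nc1ccccn1)c1c(O)c2cccnc2n(-c2ccccc2)c1=O` gives 14.6%, compound 2 `O=C(Nc1ccccc1)c1c(O)c2cccnc2n(-c2ccccc2)c1=O` gives -15%, and compound 3 `COc1ccc(NC(=O)c2c(O)c3cccnc3n(-c3ccccc3)c2=O)cn1` gives -10.2%. Compound 3 thus stands second highest of the three: the step of a number 4.8 percentage points higher from compound 2 to compound 3 (within the scatter) lies within the scatter, whereas the step of a number 24.8 percentage points lower from compound 1 to compound 3 (beyond the scatter) lies beyond it. Compound 4 `O=C(Nc1ccc(Cl)nc1)c1c(O)c2cccnc2n(-c2ccccc2)c1=O` differs from compound 3 by chloro in place of methoxy on an aromatic carbon. Within the data shown here, no measured step puts a chloro in place of a methoxy. Among the measured compounds shown here, the only step that exchanges the group on the amide-type nitrogen without touching the pyridin-2-yl of compound 1, a number 4.8 percentage points higher from compound 2 to compound 3 (within the scatter), stays within the scatter, so no step beyond the scatter is expected here either. Compound 4 is therefore estimated at -8%, between -25% and 10%, an expected step of a number 2.2 percentage points higher from compound 3 to compound 4 (within the scatter).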

Compound 4, a percentage reported as inhibition, in the whole organism at one dose (the size of the read-out at that dose, not a potency): -4%
For compound 4 the middle estimate is 4 percentage points below the measured one, within the range that was stated.
By their numbers in this assay, from the lowest: compounds 2, 3 and 4 (each within the scatter of the next, the first and the last beyond it); then compound 1.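

In this assay, the step for chloro in place of methoxy next to the ring nitrogen is a number 6.2 percentage points higher from compound 3 to compound 4 (within the scatter), so this exchange gives no readable change. Even so, the 6-chloropyridin-3-yl group of compound 4 separates from the phenyl of compound 2, with a number 11 percentage points higher from compound 2 to compound 4 (beyond the scatter), while it remains apart from the pyridin-2-yl of compound 1, with a number 18.6 percentage points lower from compound 1 to compound 4 (beyond the scatter). Nothing available explains these steps. On these data alone, whether an amine or a longer alkoxy chain at this place would move the number beyond the scatter stays open.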